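A few compounds are considered here, and "the series" means these few. Any claim that something is new, unique, unknown or untested is made for them only; others in the source may bear on it.

Notes on the series. For the measured compounds named here, compound 1 `c1ccc2c(c1)CCC2CCCN1CCN(c2cccc3c2OCCO3)CC1` is the only member with a numerical result in a functional assay on the whole organism for agonist activity, with Rattus norvegicus as the target; on this read-out lower numbers stand for an effect already at smaller amounts and higher numbers for an effect only at larger amounts of compound: in this assay compound 1 gives 10 mg/kg. Compound 2 `COc1cc2c(cc1OC)C(CCN1CCN(c3cccc4c3OCCO4)CC1)CC2` reaches only a limit of the assay in this assay, where compound 2 gives > 40 mg/kg. That limit, (the limit of > 40 mg/kg in this assay, at which 1 of the 2 values shown sits), leaves the two measured compounds without a numbered step between them, so no size of change has yet been observed in the series.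

The step from compound 1 to compound 3 `c1ccc2c(c1)CC2CCCN1CCN(c2cccc3c2OCCO3)CC1` alters the group on the chain: a group of 8 heavy atoms (8 carbon; one four-membered non-aromatic ring of carbon only, one six-membered aromatic ring of carbon only) in place of a group of 9 heavy atoms (9 carbon; one five-membered non-aromatic ring of carbon only, one six-membered aromatic ring of carbon only), on a saturated chain carbon, three bonds along the chain from an amine nitrogen in a ring. Going by the values given here, no measured pair shows a change of this kind, so the expectation rests on compound 1 alone and is for a step no larger than the scatter, or a small shift toward larger doses. In this assay compound 3 is expected to give 15 mg/kg, within a range of 5 mg/kg to 40 mg/kg. The estimated step of a 1.5-fold higher number from compound 1 to compound 3 (0.18 log units; within the scatter) is thus taken to lie close to no change.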

Compound 3, minimum effective dose: 10 mg/kg
Compound 3: middle estimate off by 1.5-fold (0.18 log units), on the high side; measured number inside the range.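

The series now has its first numbered step, no change at the digits printed from compound 1 to compound 3 (within the scatter) in this assay. On a saturated chain carbon, three bonds along the chain from an amine nitrogen in a ring, the five-membered non-aromatic ring of 2,3-dihydro-1H-inden-1-yl can thus give way to a four-membered non-aromatic ring of carbon only without a read-out change beyond the scatter. This rests on a single pair and applies only to this exchange on the core of compound 1.

Still open, on these data alone, is whether a six-membered non-aromatic ring of carbon only, an unfused phenyl group or a longer chain would leave the read-out equally unchanged at this place. Compound 2 differs from compound 1 in more than one place and stands at a limit of the assay, so no step to it can be read: the limit of > 40 mg/kg in this assay, at which 1 of the 3 values shown sits.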